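Moving the ring oxygen in a piperidine amide series

The compounds below may be only part of what the source reports. "The series", "measured", "known", "first", "only" and "open" are said of these compounds alone.

Compound 1 `O=C(Nc1ccc(OC(F)(F)F)c(F)c1)NC1CCN(C(=O)C2CCOCC2)CC1` gives 77 ug/mL in a physicochemical assay for solubility, read by mass spectrometry, in phosphate buffer, with a stated time of 24 h, at pH 7.4; on this read-out higher numbers stand for higher solubility and lower numbers for lower solubility. Compound 2 `O=C(Nc1ccc(OC(F)(F)F)c(F)c1)NC1CCN(C(=O)C2CCCOC2)CC1` differs from it by oxan-3-yl in place of oxan-4-yl on a carbonyl carbon and in this assay compound 2 gives 174 ug/mL; this change made a 2.3-fold higher number from compound 1 to compound 2 (0.35 log units; beyond the scatter). Compound 3 `O=C(Nc1ccc(C(F)(F)F)c(F)c1)NC1CCN(C(=O)C2CCOCC2)CC1` carries a different core, differing from compound 1 by trifluoromethyl in place of trifluoromethoxy on an aromatic carbon; in this assay compound 3 gives 42 ug/mL, a step of a 1.8-fold lower number from compound 1 to compound 3 (0.26 log units; within the scatter). Compound 4 `O=C(Nc1ccc(C(F)(F)F)c(F)c1)NC1CCN(C(=O)C2CCCOC2)CC1` is not yet measured; it differs from compound 3 by oxan-3-yl in place of oxan-4-yl on a carbonyl carbon, the same change that was seen between compound 1 and compound 2, made at the same place on a carbonyl carbon. Because that earlier step was a 2.3-fold higher number from compound 1 to compound 2 (0.35 log units; beyond the scatter), a similar rise is expected here, so for compound 4 the expected step is a 2.3-fold higher number from compound 3 to compound 4 (0.35 log units; beyond the scatter). The estimate for compound 4 in this assay is 95 ug/mL, likely between 45 ug/mL and 200 ug/mL.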

Compound 4, solubility: 11 ug/mL
Beside the measured number, compound 4's estimate is 8.6-fold (0.94 log units) above it, and the stated range ends above it.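

On the core of compound 3, oxan-3-yl in place of oxan-4-yl on a carbonyl carbon gave a 3.8-fold lower number from compound 3 to compound 4 (0.58 log units; beyond the scatter) in this assay, while on the core of compound 1 the same change gave a 2.3-fold higher number from compound 1 to compound 2 (0.35 log units; beyond the scatter), so here the change did not carry from one core to the other, and its direction reversed. The two core changes also differ: with oxan-4-yl the step was a 1.8-fold lower number from compound 1 to compound 3 (0.26 log units; within the scatter), but with oxan-3-yl it was a 16-fold lower number from compound 2 to compound 4 (1.20 log units; beyond the scatter). Two cores show only that the outcome of this change depended on the core in these four compounds, and no measurement shown gives a reason for it.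

Going by these compounds, whether the reversal would also appear with a nitrile in place of trifluoromethyl on the aromatic carbon remains open. So does the outcome of placing a ring bearing an amine on the carbonyl carbon.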